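A few compounds are considered here, and "the series" means these few. Any claim that something is new, unique, unknown or untested is made for them only; others in the source may bear on it.

Compound 1 `Cc1ccc(C2C(C#N)=C(N)N(c3ccc(S(N)(=O)=O)cc3)C3=C2C(=O)CCC3)cc1`: 100%
Compound 2 `COc1cc(CC2C(C#N)=C(N)N(c3ccc(S(N)(=O)=O)cc3)C3=C2C(=O)CCC3)ccc1O`: 100%

In a functional assay on Ehrlich cells (Mus musculus) for antiproliferative activity, read by trypan blue exclusion, with a stated time of 2 h, tested at 100 ug/mL (a higher number here means a stronger effect of the compound at the concentration tested, a lower number a weaker effect), compound 1 gives 100%. Its nearest measured neighbour is compound 2, which gives 100% in this assay, and the step of no change at the digits printed from compound 1 to compound 2 (within the scatter) lies within the scatter, so compound 2 stands level with compound 1.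

Compound 3 `COc1ccc2ccccc2c1C1C(C#N)=C(N)N(c2ccc(S(N)(=O)=O)cc2)C2=C1C(=O)CCC2` differs from compound 2 in one place: 2-methoxynaphthalen-1-yl in place of 4-hydroxy-3-methoxybenzyl on a saturated ring carbon. Going by the values given here, the only measured step at this position, no change at the digits printed from compound 1 to compound 2 (within the scatter), showed no change beyond the scatter. On that basis compound 3 is expected to remain level, with an estimated step of no change at the digits printed from compound 2 to compound 3 (within the scatter). The estimate for compound 3 is 100%, ranging from 85% to 100%.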

Compound 3, a percentage reported as activity, at one concentration (the size of the read-out at that concentration, not a potency): 80%
Compound 3: the middle estimate sits 20 percentage points above what was measured; measured number outside the range, below it.
By their numbers in this assay, from the lowest: compound 3; then compounds 1 and 2 (each within the scatter of the next).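

In this assay, the saturated ring carbon proves sensitive to the group it carries: 2-methoxynaphthalen-1-yl gives a number 20 percentage points lower from compound 2 to compound 3 (beyond the scatter) and a number 20 percentage points lower from compound 1 to compound 3 (beyond the scatter), whereas the earlier pair gave no step beyond the scatter. Against 4-hydroxy-3-methoxybenzyl, the entering group brings a second six-membered aromatic ring of carbon only and has no hydrogen-bond donor, and these differences arrive together, so neither can be singled out. From the compounds shown here alone, whether 2-methoxyphenyl, with a single ring, or 2-aminophenyl would keep the full read-out remains open. Nothing available explains the lower number.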